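A Small Amide Group Replaces a Large One

The source may report more compounds than this note shows. Statements on the series, on what has been measured and on what is new or still open speak of the compounds shown alone.

Measured in a physicochemical assay for lipophilicity, at pH 7.4; on this read-out lower numbers stand for lower lipophilicity and higher numbers for higher lipophilicity:
Compound 1 `CNC(=O)c1cc(C(=O)N[C@H]2[C@@H]3C[C@H](O)C[C@@H]32)cc2c1OC[C@@]2(C)c1ccccc1`: 3.7
Compound 2 `CCC(=O)N1C[C@@H]2[C@H](C1)[C@H]2NC(=O)c1cc(C(=O)NC)c2c(c1)[C@H](c1ccccc1)CO2`: 3.4
Compound 3 `CNC(=O)c1cc(C(=O)N[C@H]2C[C@@H]2C)cc2c1OC[C@@]2(CO)c1ccccc1`: 3.3

Compound 2, at 3.4, lies within the usual scatter of both compound 3 and compound 1, so the numbers do not clearly separate it from either. Compound 4 `CNC(=O)c1cc(C(=O)NC)c2c(c1)[C@H](c1ccccc1)CO2` has not yet been measured in this assay. It differs from compound 2 in one place, on an amide-type nitrogen: one carbon atom in place of a group of 10 heavy atoms (8 carbon, 1 nitrogen, 1 oxygen; one three-membered non-aromatic ring of carbon only, one five-membered non-aromatic ring with 1 hetero atom), on an amide-type nitrogen. The group that enters there is a methyl.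

For the measured compounds named here, no two measured compounds differ in just one place, so no measured step can serve as a direct guide. One weak clue remains: compound 2, at 3.4, carries the large group, while compound 3, at 3.3, lacks it, and the two still sit within the scatter. A modest fall, no larger than the scatter, is therefore expected, with the estimate being a number 0.20 log units lower from compound 2 to compound 4 (within the scatter). The expected value for compound 4 is 3.2, with an estimated range from 2.7 to 3.7.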

Compound 4, distribution coefficient: 3.2
Beside the measured number, compound 4's estimate shows no gap at the digits printed; the range from low to high includes it.
By their numbers in this assay, from the lowest: compounds 4, 3, 2 and 1 (each within the scatter of the next, the first and the last beyond it).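

For the compounds shown here, this is the first direct comparison at this place, on an amide-type nitrogen whose other neighbour is a carbonyl carbon. In this assay, replacing the group of 10 heavy atoms, with its two non-aromatic rings and 3 defined stereocentres, by a methyl gives a number 0.20 log units lower from compound 2 to compound 4 (within the scatter), so a very large cut in size at this nitrogen produces no clear change in the read-out. Nothing measured here offers an explanation for this result.

The compounds shown leave open how the read-out responds to other groups on this nitrogen, such as a longer chain like propyl, an amine or a carboxylic acid. Compound 1 and compound 3 each differ from compound 4 in more than one place, so this single pair cannot say whether the same swap behaves alike on other cores.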